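A Dichlorophenyl Swap on the Piperazine Side Chain

The source may hold more compounds than are shown below. What is called first, only, known or untested is meant among the compounds shown, and "the series" means these compounds.

Compound 1 `CCC1(CCCCN2CCN(c3cccc(OC)c3)CC2)C(=O)Nc2ccccc21` was tested in a functional assay on the whole organism (strain Wistar) with Rattus norvegicus as the target, with a stated time of 5 min; on this read-out lower numbers stand for an effect already at smaller amounts and higher numbers for an effect only at larger amounts of compound. For compound 1 the read-out is only a limit of the assay, > 20 mg/kg, so no exact number is known. Compound 2 `CCC1(CCCCN2CCN(c3ccc(Cl)cc3)CC2)C(=O)Nc2cc(F)ccc21` likewise gives only a limit in this assay, > 20 mg/kg. Compound 3 `O=C1Nc2ccccc2C1CCCCN1CCN(c2cccc(Cl)c2)CC1` reaches the other limit, < 5 mg/kg. Of the three results shown, two sit at the limit of > 20 mg/kg in this assay, at which 2 of the 3 values shown sit, and one at the limit of < 5 mg/kg in this assay, at which 1 of the 3 values shown sits, and compound 1 belongs to the pair at the upper limit.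

Compound 4 `CCC1(CCCCN2CCN(c3ccc(Cl)c(Cl)c3)CC2)C(=O)Nc2ccccc21` has not been measured. It differs from compound 1 in a single place: 3,4-dichlorophenyl in place of 3-methoxyphenyl on an amine nitrogen in a ring. Going by the values given here, no two measured compounds differ in only one place, so no measured step tells what this kind of swap does; compound 2 and compound 3 differ from each other in several places at once and show only that both limits occur. The step from compound 1 to compound 4 is therefore expected to be modest, an at least 1.3-fold lower number from compound 1 to compound 4 (0.12 log units; that floor lies within the scatter), with the direction uncertain. Compound 4 is estimated at 15 mg/kg, with a range from 5 mg/kg to 40 mg/kg.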

Compound 4, minimum effective dose: > 20 mg/kg
Compound 4: no number, only a limit; the forecaster's own chance of this, stated with the estimate: 50%; middle value at least 1.3-fold (0.12 log units) away from the limit.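

Compound 1 and compound 4 each give only a limit in this assay, not a number, so the step between them cannot be read. The compounds shown leave open whether 3,4-dichlorophenyl or 3-methoxyphenyl gives an effect at the smaller dose.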